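Swapping cyclopropylmethyl for 3-fluorophenyl: clearance outlook

The source may hold more compounds than are shown below. What is called first, only, known or untested is meant among the compounds shown, and "the series" means these compounds.

Of the compounds shown here, two have so far been tested in an ADME assay on microsomes from liver (Homo sapiens) for pharmacokinetics; on this read-out higher numbers stand for fast clearance and lower numbers for slow clearance. Compound 1, `CCC(=O)N1CCN(c2nc(-c3cnn(C)c3)ncc2C#N)C[C@H]1C`, gives < 16 mL/min/kg, which is a limit of the assay rather than a number. Compound 2, `Cn1cc(-c2ncc(C#N)c(N3C[C@@H]4C[C@H]3CN4CC3CC3)n2)cn1`, gives < 16 mL/min/kg, again a limit of the assay. Compound 2 thus stands at the limit of < 16 mL/min/kg in this assay, at which 2 of the 2 values shown sit. Nothing in these numbers places compound 2 apart from compound 1 on this read-out. Compound 3, `Cn1cc(-c2ncc(C#N)c(N3C[C@@H]4C[C@H]3CN4c3cccc(F)c3)n2)cn1`, is not yet measured; it differs from compound 2 by 3-fluorophenyl in place of cyclopropylmethyl on an amine nitrogen in a ring. Going by the values given here, no measured pair shows what such a change does in this assay, so the expectation rests on the structural change alone. The step of an at least 1.2-fold higher number from compound 2 to compound 3 (0.09 log units; that floor lies within the scatter) is expected to be a modest rise in clearance, one that may not exceed the usual scatter. Compound 3 is therefore estimated at 20 mL/min/kg, within a plausible range from 9 mL/min/kg to 45 mL/min/kg.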

Compound 3, clearance: 76 mL/min/kg
Compound 3: the middle estimate sits 3.8-fold (0.58 log units) below what was measured; measured number above the stated range.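

On an amine nitrogen in a ring, 3-fluorophenyl in place of cyclopropylmethyl gives an at least 4.7-fold higher number from compound 2 to compound 3 (0.67 log units; beyond the scatter) in this assay, so what this position carries can matter for clearance. Going by these compounds alone, compound 3 also provides the first value here that is a number rather than a limit, which shows that this read-out can respond to a change at this place. The size of the step is only a floor, as compound 2 stands at a limit and not at a number: the limit of < 16 mL/min/kg in this assay, at which 2 of the 3 values shown sit.

The pair cannot separate the contribution of the aromatic ring from that of the fluorine, and it gives no cause for the rise. A plain phenyl group would address the first question, while a benzyl group would show whether a carbon link between the nitrogen and the aromatic ring alters the outcome.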